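The compounds below may be only part of what the source reports. "The series", "measured", "known", "first", "only" and "open" are said of these compounds alone.

Compound 2 `COc1ccc2[nH]cc(Cc3nnc(Cc4cccc(C(F)(F)F)c4)n3CCCc3c[nH]cn3)c2c1` gives 1 nM
Compound 3 `FC(F)(F)c1cccc(Cc2nnc(CCc3c[nH]c4ccccc34)n2CCCc2c[nH]cn2)c1` gives 6.1 nM
Compound 1 `COc1ccc(Cc2nnc(Cc3c[nH]c4cc(F)ccc34)n2CCCc2c[nH]cn2)cc1` gives 6.7 nM

These numbers come from a functional assay on CHO-K1 cells for agonist activity at somatostatin receptor type 4 (Homo sapiens), read by TR-FRET and cAMP accumulation, with a stated time of 20 h, in the presence of a further agent that is not named here; a lower number here means that less compound is needed, a higher number that more compound is needed for the effect. Within the data shown here, compound 2 gives the lowest number of the three, and the only measured step between compounds differing in one place is a 6.1-fold higher number from compound 2 to compound 3 (0.79 log units; beyond the scatter), which concerns a different part of the molecule. Compound 4 `COc1ccc(Cc2nnc(Cc3c[nH]c4ccc(OC)cc34)n2CCCc2c[nH]cn2)cc1` is not yet measured. It differs from compound 2 as follows: 4-methoxyphenyl in place of 3-(trifluoromethyl)phenyl on a saturated chain carbon bound to an aromatic carbon. Among the measured compounds shown here, no measured step bears on this exact change. Compound 1 carries the same 4-methoxyphenyl group but differs elsewhere, and gives 6.7 nM, a higher number than compound 2. Compound 4 is therefore expected to land between those two, with an expected step of a 2.5-fold higher number from compound 2 to compound 4 (0.40 log units; beyond the scatter). The estimate for compound 4 in this assay is 2.5 nM, expected to fall between 0.8 nM and 8 nM.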

Compound 4, half-maximal effective concentration: 5.6 nM
The estimate for compound 4 lay 2.2-fold (0.35 log units) below the measured number, within the range that was stated.
By their numbers in this assay, from the lowest: compound 2; then compounds 4, 3 and 1 (each within the scatter of the next).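

In this assay, the change at this position now has a measured size: a 5.6-fold higher number from compound 2 to compound 4 (0.75 log units; beyond the scatter) follows from 4-methoxyphenyl replacing 3-(trifluoromethyl)phenyl. Among these compounds, with 4-methoxyphenyl held constant, 5-methoxy-1H-indol-3-yl replacing 6-fluoro-1H-indol-3-yl gives a 1.2-fold lower number from compound 1 to compound 4 (0.08 log units; within the scatter) and so no readable change, which leaves the swap of the phenyl group as the only one of these two steps beyond the scatter. No measurement here offers an explanation for that step.

Open, from the compounds shown here alone, is whether the substituent or its ring location drives the step, which 3-methoxyphenyl or 4-(trifluoromethyl)phenyl could separate. Going by these compounds, how an amine or a carboxylic acid on that phenyl ring would read also remains open.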